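The source may hold more compounds than are shown below. What is called first, only, known or untested is meant among the compounds shown, and "the series" means these compounds.

Compound 1 `Nc1ccccc1NC(=O)c1ccc(CSC(=S)N2CCN(Cc3ccccn3)CC2)cc1`: in a functional assay on MGC-803 cells (Homo sapiens) for antiproliferative activity, read by CCK-8 assay, with a stated time of 72 h, tested at 8 uM (a higher number here means a stronger effect of the compound at the concentration tested, a lower number a weaker effect), compound 1 gives 65.2%.
Compound 2 `COc1ccc(N2CCN(C(=S)SCc3ccc(C(=O)Nc4ccccc4N)cc3)CC2)cc1`: in this assay compound 2 gives 22.9%.
Compound 3 `Nc1ccccc1NC(=O)c1ccc(CSC(=S)N2CCN(c3ncccn3)CC2)cc1`: in this assay compound 3 gives 64.8%.

Among these three numbers compound 3 stands second highest. Its nearest neighbour is compound 1, and the step of a number 0.4 percentage points lower from compound 1 to compound 3 (within the scatter) lies within the scatter, so the two cannot be told apart. Its furthest neighbour is compound 2, and the step of a number 41.9 percentage points higher from compound 2 to compound 3 (beyond the scatter) is large and beyond the scatter. All three compounds share one core and differ only in the group carried on an amine nitrogen in a ring.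

Compound 4 `Nc1ccccc1NC(=O)c1ccc(CSC(=S)N2CCN(Cc3cccnc3)CC2)cc1` has not yet been measured. It differs from compound 3 in one place: (pyridin-3-yl)methyl in place of pyrimidin-2-yl on an amine nitrogen in a ring. Within the data shown here, two measured steps bear on this change. The step of a number 0.4 percentage points lower from compound 1 to compound 3 (within the scatter) shows that exchanging (pyridin-2-yl)methyl for pyrimidin-2-yl moved nothing beyond the scatter, while the step of a number 42.3 percentage points lower from compound 1 to compound 2 (beyond the scatter) shows that 4-methoxyphenyl at the same place lowered the number heavily. The group entering in compound 4 is built like the (pyridin-2-yl)methyl of compound 1, not like the 4-methoxyphenyl of compound 2, so the expected step of a number 4.8 percentage points lower from compound 3 to compound 4 (within the scatter) is none beyond the scatter. Compound 4 is therefore estimated to give 60%, with a range from 42% to 76%.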

Compound 4, a percentage reported as inhibition, at one concentration (the size of the read-out at that concentration, not a potency): 64.6%
The estimate for compound 4 lay 4.6 percentage points below the measured number; low and high end bracket the measured number.
By their numbers in this assay, from the lowest: compound 2; then compounds 4, 3 and 1 (each within the scatter of the next).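

In this assay, among these compounds, pyridin-3-yl in place of pyridin-2-yl on a saturated chain carbon bound to an amine nitrogen in a ring gives a number 0.6 percentage points lower from compound 1 to compound 4 (within the scatter), so this comparison offers the first look at where the pyridine ring is attached, and the read-out does not separate the two forms. Setting (pyridin-3-yl)methyl in place of pyrimidin-2-yl gives a number 0.2 percentage points lower from compound 3 to compound 4 (within the scatter), while setting it in place of 4-methoxyphenyl gives a number 41.7 percentage points higher from compound 2 to compound 4 (beyond the scatter), so three different groups on this ring nitrogen now cannot be told apart and compound 2 alone stands apart from the others. Nothing measured here explains why these groups read alike or why 4-methoxyphenyl differs.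

Each number comes from a single concentration, so compounds that read alike here could still show a stronger or weaker effect at other concentrations. Going by these compounds, it also remains open whether the methoxy group or the directly attached benzene ring goes with the low number of compound 2, a question that a plain phenyl or a 4-methoxybenzyl group on the same nitrogen would address.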